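Swapping a Chloro for a Methyl on the Core

A few compounds are considered here, and "the series" means these few. Any claim that something is new, unique, unknown or untested is made for them only; others in the source may bear on it.

Of the compounds shown here, three built on a shared core have been measured in an assay for inhibition of NT-3 growth factor receptor (Homo sapiens), read by HTRF, with a stated time of 40 min, in the presence of a further agent that is not named here; a higher number here means a weaker inhibitor, a lower number a stronger inhibitor. Compound 1, `Cc1cc(Nc2nc(NCc3cc(F)ccc3F)nc3ccccc23)n[nH]1`, gives 2.5 nM. Compound 2, `Fc1ccc(CNc2nc(Nc3cc(C4CC4)[nH]n3)c3ccccc3n2)c(F)c1`, gives 75 nM. Compound 3, `Cc1cc(Nc2nc(NCc3ccc(F)cc3F)nc3cc(Cl)ccc23)n[nH]1`, gives 23 nM. Among these three numbers compound 3 holds the second highest place: its value lies between that of compound 1 and that of compound 2, nearer to compound 2, and both gaps are beyond the usual scatter of repeated measurements.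

Compound 4, `Cc1ccc2c(Nc3cc(C)[nH]n3)nc(NCc3ccc(F)cc3F)nc2c1`, has not yet been measured. It differs from compound 3 in one place: methyl in place of chloro on an aromatic carbon. For the measured compounds named here, both groups are single heavy atoms without donors, acceptors or charge, and no measured pair shows what this exchange does on this core. The expected step from compound 3 to compound 4 in this assay is therefore small, a 1.5-fold lower number from compound 3 to compound 4 (0.19 log units; within the scatter), either within the scatter or a slight move toward a lower number. Compound 4 is estimated at 15 nM, with a plausible range from 5 nM to 45 nM.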

Compound 4, half-maximal inhibitory concentration: 12 nM
Compound 4: the middle estimate sits 1.3-fold (0.10 log units) above what was measured; low and high end bracket the measured number.
By their numbers in this assay, from the lowest: compound 1; then compounds 4 and 3 (each within the scatter of the next); then compound 2.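

In this assay, for the compounds shown here, the only pair that differs in one place gives a 1.9-fold lower number from compound 3 to compound 4 (0.28 log units; within the scatter) and so offers the first direct reading of this aromatic carbon. At this carbon of the shared core, methyl and chloro cannot be told apart, since the numbers of the two compounds lie within the usual scatter of repeated measurements. Nothing at hand offers a cause for this result.

A single exchange between two groups of one heavy atom each says little about the position as a whole. On these data alone, what a plain hydrogen, a methoxy group or an amine would do at this same carbon stays open, as does whether methyl and chloro would also read alike with the cyclopropyl group of compound 2 in place of the methyl on the five-membered ring.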